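The compounds below may be only part of what the source reports. "The series", "measured", "known", "first", "only" and "open" are said of these compounds alone.

In a functional assay on RT-112 cells (Homo sapiens) for antiproliferative activity (a higher number here means a weaker inhibitor, a lower number a stronger inhibitor), compound 1 (`COc1cc(N(CCCSC(=S)N2CCN(C(C)=O)CC2)S(=O)(=O)c2cccc3cccnc23)cc(OC)c1OC`) gives 700 nM. Compound 2 (`COc1cc(N(CCCSC(=S)N2CCN(C)CC2)S(=O)(=O)c2cccc3cccnc23)cc(OC)c1OC`) stands level with it at 700 nM. Compound 3 (`CCN1CCN(C(=S)SCCCN(c2cc(OC)c(OC)c(OC)c2)S(=O)(=O)c2cccc3cccnc23)CC1`) departs from compound 2 by methyl in place of hydrogen on a saturated chain carbon bound to an amine nitrogen in a ring, with methyl in place of hydrogen on a saturated chain carbon bound to an amine nitrogen in a ring, so that 4-methylpiperazin-1-yl becomes 4-ethylpiperazin-1-yl. Among the measured compounds shown here, the one measured step that bears on this change, methyl in place of acetyl on an amine nitrogen in a ring, is no change at the digits printed from compound 1 to compound 2 (within the scatter). On that single step, the expected result in this assay is no change at the digits printed from compound 2 to compound 3 (within the scatter), with no shift in either direction beyond the scatter. For compound 3 the estimated value is 700 nM, with an expected range of 300 nM to 1600 nM.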

Compound 3, half-maximal inhibitory concentration: 700 nM
For compound 3 middle estimate and measured number coincide at the digits printed; the range from low to high includes it.
By their numbers in this assay, from the lowest: compounds 1, 2 and 3 (each within the scatter of the next).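

In this assay the change to 4-ethylpiperazin-1-yl gives no change at the digits printed from compound 2 to compound 3 (within the scatter) and ethyl in place of acetyl gives no change at the digits printed from compound 1 to compound 3 (within the scatter) on the amine nitrogen in the ring. This position now carries acetyl, methyl and ethyl with the same printed value, so adding a methyl on the saturated chain carbon joins the earlier swap of acetyl for methyl in leaving the number level. No evidence is at hand to account for this. As far as these compounds go, whether a benzyl group, a longer chain or a carboxylic acid on this nitrogen would also leave the number level stays open.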